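A Phenyl Ester Exchanged for a Dimethylamide

The source may report more compounds than this note shows. Statements on the series, on what has been measured and on what is new or still open speak of the compounds shown alone.

Of the compounds shown here, two have numbers so far. Compound 1 `COc1ccc(COCC(Cn2ccnc2)OCc2ccc(C(=O)Oc3ccccc3)cc2)cc1` gives in a functional assay for inhibition of Thromboxane-A synthase (Homo sapiens) (a higher number here means a weaker inhibitor, a lower number a stronger inhibitor), a value of 560 nM, the lower of the two. Compound 2 `COc1ccc(COCC(Cn2ccnc2)OCc2ccc3c(c2)COC3=O)cc1` gives in this assay 6200 nM, a gap from compound 1 that lies well beyond the usual scatter. Compound 3 `COc1ccc(COCC(Cn2ccnc2)OCc2ccc(C(=O)N(C)C)cc2)cc1` is the next one to be measured, and it differs from compound 1 in a single place: dimethylamino in place of phenoxy on a carbonyl carbon. Within the data shown here, no step of this kind has yet been measured, so the direction can only be guessed. Since compound 2, which also alters the carbonyl end of the molecule, gives 6200 nM, a move toward weaker inhibition is considered more likely than a gain. For compound 3 the expected step is a 2.7-fold higher number from compound 1 to compound 3 (0.43 log units; beyond the scatter). Compound 3 is therefore estimated at 1500 nM, within a range from 400 nM to 6000 nM.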

Compound 3, half-maximal inhibitory concentration: 1940 nM
Estimate against measurement, compound 3: 1.3-fold (0.11 log units) below; the measured number falls inside the stated range.
By their numbers in this assay, from the lowest: compound 1; then compound 3; then compound 2.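

Among these compounds, exchanging phenoxy for dimethylamino on a carbonyl carbon gives a 3.5-fold higher number from compound 1 to compound 3 (0.54 log units; beyond the scatter) in this assay, the first change that can be read at a single place. It shows that the group on this carbonyl carbon affects the number, and that the lower value of compound 1 goes with phenoxy rather than dimethylamino. It also shows that the six-membered aromatic ring of phenoxy is not needed for compound 3 to give a measurable value, while nothing available here accounts for the size of the step.

The compounds shown leave open whether the ring or the ester oxygen goes with the lower number, a question that phenylamino or methoxy on the same carbonyl carbon would separate. From the compounds shown here alone, how a carboxylic acid or a primary amide at this place would read also remains unknown.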